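Chloro in Place of Methyl on the Weaker Analogue

The compounds below may be only part of what the source reports. "The series", "measured", "known", "first", "only" and "open" are said of these compounds alone.

Of the compounds shown here, two that share one core have been tested. Compound 1 `Cc1ncn(-c2cc(NC(=O)c3ccc(C)c(Nc4nc(-c5cccnc5)cs4)c3)cc(C(F)(F)F)c2)n1` and compound 2 `Cc1cc(NC(=O)c2ccc(C)c(Nc3nc(-c4cccnc4)cs3)c2)cc(-n2cnc(C)c2)c1` were measured in a functional assay on KU812 cells (Homo sapiens) for antiproliferative activity; on this read-out lower numbers stand for stronger inhibition and higher numbers for weaker inhibition. Compound 1 gives 38 nM, while compound 2 gives 871 nM, the higher of the two numbers, and the gap between them lies beyond the scatter. Compound 3 `Cc1cn(-c2cc(Cl)cc(NC(=O)c3ccc(C)c(Nc4nc(-c5cccnc5)cs4)c3)c2)cn1` differs from compound 2 in a single spot: chloro in place of methyl on an aromatic carbon. Within the data shown here, no measured pair isolates this swap, so only a small shift is expected, a 1.5-fold lower number from compound 2 to compound 3 (0.16 log units; within the scatter), in either direction or none beyond the scatter. Compound 3 is therefore expected to give about 600 nM, within a range from 200 nM to 2000 nM.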

Compound 3, half-maximal inhibitory concentration: 518 nM
For compound 3 the middle estimate is 1.2-fold (0.06 log units) above the measured one; the range from low to high includes it.
By their numbers in this assay, from the lowest: compound 1; then compounds 3 and 2 (each within the scatter of the next).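

In this assay, placing chloro instead of methyl on this aromatic carbon, meta to a 4-methyl-1H-imidazol-1-yl group, gives a 1.7-fold lower number from compound 2 to compound 3 (0.23 log units; within the scatter). This step lies within the scatter, so the read-out does not separate these two groups at this position, and the swap is tolerated without a clear gain or loss. No measurement shown here offers an explanation for this result.

Still open, from the compounds shown here alone, is how a group of a different kind at this position, such as an amine, a methoxy group or a carboxylic acid, would read out. Also open, going by these compounds, is whether chloro and methyl would match as closely on a different core.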